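The source may hold more compounds than are shown below. What is called first, only, known or untested is meant among the compounds shown, and "the series" means these compounds.

Measured compounds:
Compound 1 `CC(C)N(Cc1cccc(OCCCCCC(=O)O)c1)C(=O)c1ccc(-c2ccco2)cc1` in an ADME assay on BJ cells (Homo sapiens) for cytotoxicity, read by CellTiter-Glo and resazurin assay, with a stated time of 72 h; on this read-out lower numbers stand for an effect already at smaller amounts and higher numbers for an effect only at larger amounts of compound: > 26000 nM
Compound 2 `CC(C)N(Cc1cccc(OCCCCCC(=O)O)c1)C(=O)c1ccc(-c2cccc(Oc3ccccc3)c2)cc1` in this assay : > 18700 nM

Neither of these two values is a number in the ordinary sense. For compound 1 the figure is a limit of the assay: no effect was seen up to the highest amount tested, as the limit of > 26000 nM in this assay, at which 1 of the 2 values shown sits, records. For compound 2 the figure is likewise a limit, as the limit of > 18700 nM in this assay, at which 1 of the 2 values shown sits, records, so compound 2 stands at the edge of what this assay can report, with no effect found within the tested range.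

Compound 3 `COc1cccc(-c2ccc(C(=O)N(Cc3cccc(OCCCCCC(=O)O)c3)C(C)C)cc2)c1` is not yet measured. It differs from compound 2 in one place: methyl in place of phenyl on an oxygen on an aromatic ring, or phenoxy to methoxy. Going by the values given here, since the two measured compounds both sit at a limit, no step between them can be read, and the change from compound 2 to compound 3 is expected to give no shift beyond the usual scatter, with the result most likely again a limit.

Compound 3 is therefore expected at about 30000 nM in this assay, with a range from 15000 nM to 100000 nM. The step this implies, a step that the limit leaves unreadable from compound 2 to compound 3, is an estimate only.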

Compound 3, half-maximal effective concentration: > 20900 nM
Compound 3 was reported as a limit; the forecaster's own chance of this, stated with the estimate: 85%; the middle value lies beyond the limit too.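

Going by these compounds alone, compound 1, compound 2 and compound 3 are all reported as limits in this assay, not as numbers, so no step among them can be read. The compounds shown leave open how far apart the three really lie, and at what amount, if any, each of them would show an effect.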